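The source may report more compounds than this note shows. Statements on the series, on what has been measured and on what is new or still open speak of the compounds shown alone.

Measured so far:
compound 1 `Cc1ccc2c(NCc3ccc(NC(=O)C4CCN(Cc5ccccc5)CC4)cc3)nc(N3CCN[C@@H](C)C3)nc2c1` gives only a limit in a functional assay on SV5A8 cells (Homo sapiens) for cytotoxicity; a lower number here means a stronger inhibitor, a higher number a weaker inhibitor: > 8860 nM
compound 2 `Cc1ccc2c(NCc3ccc(NC(=O)C4CCN(Cc5ccco5)CC4)cc3)nc(N(C)C)nc2c1` gives only a limit in this assay: > 20000 nM
compound 3 `Cc1ccc2c(NCc3ccc(NC(=O)C4CCN(Cc5ccc(F)cc5)CC4)cc3)nc(N(C)C)nc2c1` gives only a limit in this assay: > 4820 nM

Every value shown in this assay is a limit of the assay, not a number. Compound 1 sits at the limit of > 8860 nM in this assay, at which 1 of the 3 values shown sits. Compound 2 sits at the limit of > 20000 nM in this assay, at which 1 of the 3 values shown sits. Compound 3 sits at the limit of > 4820 nM in this assay, at which 1 of the 3 values shown sits. Among the measured compounds shown here, the only step between measured compounds, a step that the two limits leave unreadable from compound 2 to compound 3, changes the group on the saturated chain carbon bound to the ring amine nitrogen and cannot be read in size.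

Compound 4 `Cc1ccc2c(NCc3ccc(NC(=O)C4CCN(Cc5ccccc5)CC4)cc3)nc(N3CCC3)nc2c1` differs from compound 1 by azetidin-1-yl in place of 3-methylpiperazin-1-yl on an aromatic carbon. For the measured compounds named here, no measured step touches this aromatic carbon, so nothing bears on the change directly; the series gives no readable step in either direction. Compound 4 is expected to give 15000 nM, range 5000 nM to 50000 nM, most probably again as a limit. The estimated step that the limit leaves unreadable from compound 1 to compound 4 is expected to be none beyond the scatter.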

Compound 4, half-maximal inhibitory concentration: > 8500 nM
Compound 4: only a limit was reported; the forecaster's own chance of this, stated with the estimate: 75%; the middle value is on the limit's open side.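

Compound 1 and compound 4 both give only limits in this assay, so the step between them cannot be read. The compounds shown leave open at what concentration any of them inhibits these cells.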